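Fluorinated chain extension on a thiochromane acid scaffold

A few compounds are considered here, and "the series" means these few. Any claim that something is new, unique, unknown or untested is made for them only; others in the source may bear on it.

Compound 1 `C[C@]1(c2ccc(O)cc2)CSc2cc(O)ccc2[C@H]1CCCCCCCCC(CCCC(F)(F)C(F)(F)F)C(=O)O` and compound 2 `C[C@]1(c2ccc(O)cc2)CSc2cc(O)ccc2[C@H]1CCCCCCCCC(CCCC(F)(F)C(F)(F)C(F)(F)C(F)(F)F)C(=O)O` share one core, while compound 3 `C[C@]1(c2ccc(O)cc2)CSc2cc(O)ccc2[C@H]1CCCCCCCCCC(CCCC(F)(F)C(F)(F)F)C(=O)O` and the unmeasured compound 4 `C[C@]1(c2ccc(O)cc2)CSc2cc(O)ccc2[C@H]1CCCCCCCCCC(CCCC(F)(F)C(F)(F)C(F)(F)C(F)(F)F)C(=O)O` share another; the difference between the two cores is not broken down here. In a functional assay on the whole organism for antagonist activity, with Mus musculus as the target, at a dose of 10 mg/kg by the oral route (on this read-out lower numbers stand for a weaker effect and higher numbers for a stronger effect at the one dose given), compound 1 gives 77% and compound 2 gives 93%. The change 1,1,2,2,2-pentafluoroethyl in place of fluoro on a saturated chain carbon bound to two fluorine atoms and a saturated chain carbon gives the step of a number 16 percentage points higher from compound 1 to compound 2 (beyond the scatter). In this assay compound 3 gives 81%. Compound 4 carries the same change, (1,1,2,2,2-pentafluoroethyl in place of fluoro on a saturated chain carbon bound to two fluorine atoms and a saturated chain carbon). The step from compound 3 to compound 4 is expected to be of a similar direction but somewhat smaller, a number 11 percentage points higher from compound 3 to compound 4 (beyond the scatter), because compound 3 already stands at 81% and the read-out cannot exceed full inhibition. Compound 4 is therefore estimated at 92%, between 84% and 98%.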

Compound 4, a percentage reported as inhibition, in the whole organism at one dose (the size of the read-out at that dose, not a potency): 86%
Beside the measured number, compound 4's estimate is 6 percentage points above it; the range from low to high includes it.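

On the core of compound 3, putting 1,1,2,2,2-pentafluoroethyl in place of fluoro gives a number 5 percentage points higher from compound 3 to compound 4 (within the scatter) in this assay. Set beside the earlier step, the two cores cannot be told apart on this change: the same change on two cores in this assay, a number 16 percentage points higher (beyond the scatter) from compound 1 to compound 2 and a number 5 percentage points higher (within the scatter) from compound 3 to compound 4, 11 percentage points apart, within the scatter of two such steps. This is consistent with the change carrying over from one core to the other, but it does not show that the two steps are equal, and on the core of compound 3 the step alone cannot be told from no change.

The compounds shown leave open how the change behaves with an amide in place of the carboxylic acid, or with a longer fluorinated chain. Going by these compounds, how these steps look at other doses also remains open.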